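The source may hold more compounds than are shown below. What is called first, only, known or untested is meant among the compounds shown, and "the series" means these compounds.

Compound 1 `CCCCCCCCNc1nccnc1C(=O)NCc1ccccc1`: in an ADME assay on HeLa cells (Homo sapiens) for cytotoxicity, read by microscopy, with a stated time of 6 days (on this read-out lower numbers stand for higher toxicity in this test and higher numbers for lower toxicity in this test), compound 1 gives > 100000 nM, which is a limit of the assay rather than a number.
Compound 2 `CCCCNc1nccnc1C(=O)NCc1ccccc1`: in this assay compound 2 gives > 100000 nM, again a limit and not a number.
Compound 3 `O=C(NCc1ccccc1)c1nccnc1Cl`: in this assay compound 3 gives "not determined" (no result reported).

Compound 3 therefore has no place on the scale: of the three compounds, two sit at the same limit, as the limit of > 100000 nM in this assay, at which 2 of the 3 values shown sit, records, and compound 3 itself has no result at all. For the measured compounds named here, the one step that can be drawn between measured compounds, a step that the two limits leave unreadable from compound 1 to compound 2, gives no readable size, since both ends are limits.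

The step to the unmeasured compound 4 `CCCCCCCNc1nccnc1C(=O)NCc1ccccc1` replaces one small group with a chain: heptylamino in place of chloro on an aromatic carbon. Going by the values given here, this change has no direct counterpart among the measured pairs. The nearest comparison is that the octylamino compound 1 and the butylamino compound 2, which bracket the heptylamino chain of compound 4 in length, both stop at the limit in this assay. Among the compounds with values here, no step here shows a size in either direction, so no move beyond the scatter is expected; the most likely outcome is another limit.

Compound 4 is thus estimated to give 100000 nM in this assay, with an expected range from 25000 nM to 100000 nM.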

Compound 4, minimum cytotoxic concentration: > 100000 nM
Compound 4: no number, only a limit; the forecaster's own chance of this, stated with the estimate: 85%; the middle value lies on the limit itself.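

Compound 4 stops at the same assay limit as compound 1 and compound 2, so no step among these three compounds can be read: the limit of > 100000 nM in this assay, at which 3 of the 4 values shown sit.

The compounds shown leave open whether any amino chain on the shared core would give a readable number in this assay, and where chloro compound 3 would stand.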